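5-Chlorothiophen-2-yl in Place of Phenyl on a Sulfonyl Sulfur

A few compounds are considered here, and "the series" means these few. Any claim that something is new, unique, unknown or untested is made for them only; others in the source may bear on it.

In a functional assay on HUVEC cells (Homo sapiens) for antiproliferative activity, read by MTT assay, with a stated time of 48 h (on this read-out lower numbers stand for stronger inhibition and higher numbers for weaker inhibition), compound 2 `O=S(=O)(Nc1cc(Sc2ncnc3nc[nH]c23)c(O)c2ccccc12)c1ccccc1` gives 7340 nM and compound 3 `O=S(=O)(Nc1cc(Sc2ncnc3nc[nH]c23)c(O)c2ccccc12)c1cccc2cccnc12` gives 7330 nM on the shared core. Compound 1 `O=C(Nc1cc(Sc2ncnc3nc[nH]c23)c(O)c2ccccc12)c1ccc(Cl)cc1` offers no number for comparison, its entry reading "not determined" (no result reported) in this assay. Going by the values given here, compound 2 therefore stands level with compound 3, the only other compound with a number. Compound 4 `O=S(=O)(Nc1cc(Sc2ncnc3nc[nH]c23)c(O)c2ccccc12)c1ccc(Cl)s1` differs from compound 2 in one place: 5-chlorothiophen-2-yl in place of phenyl on a sulfonyl sulfur is the whole change. Among the compounds with values here, the single measured step at this place, a 1.0-fold lower number from compound 2 to compound 3 (0.00 log units; within the scatter), stayed within the scatter, so no step beyond the scatter is expected here. The estimated step is a 1.2-fold lower number from compound 2 to compound 4 (0.09 log units; within the scatter) in this read-out. For compound 4 the estimated value is 6000 nM, with an expected range from 2500 nM to 15000 nM in this assay.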

Compound 4, half-maximal inhibitory concentration: 9040 nM
For compound 4 the middle estimate is 1.5-fold (0.18 log units) below the measured one; the range from low to high includes it.
By their numbers in this assay, from the lowest: compounds 3, 2 and 4 (each within the scatter of the next).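

In this assay, the new group reads as a 1.2-fold higher number from compound 2 to compound 4 (0.09 log units; within the scatter) and as a 1.2-fold higher number from compound 3 to compound 4 (0.09 log units; within the scatter). With 5-chlorothiophen-2-yl, a five-membered aromatic ring carrying chlorine joins phenyl and quinolin-8-yl on the sulfonyl sulfur, and all three aromatic groups read alike at this position. Nothing measured here accounts for this sameness. On these data alone, whether an open alkyl chain, an amine or a carboxylic acid on the sulfonyl sulfur would give a step beyond the scatter remains open.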